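Swapping cyclopropyl for methoxymethyl on a shared core

The source may hold more compounds than are shown below. What is called first, only, known or untested is meant among the compounds shown, and "the series" means these compounds.

Of the compounds shown here, two with the same core have been measured so far in a physicochemical assay for solubility, measured as kinetic solubility; a higher number here means a more soluble compound, a lower number a less soluble compound. Compound 1 `C[C@H](NC(=O)c1cc(C(F)(F)F)nn1C)c1nc(-c2ccnc(N(C)C)c2)no1` gives 28000 nM. Compound 2 `C[C@H](NC(=O)c1cc(C(F)(F)F)nn1C)c1nc(-c2ccnc(C3CC3)c2)no1`, with cyclopropyl in place of dimethylamino on an aromatic carbon, gives 16000 nM. These two numbers lie within the scatter of each other, so compound 2 cannot be told apart from compound 1.

Compound 3 `COCc1cc(-c2noc([C@H](C)NC(=O)c3cc(C(F)(F)F)nn3C)n2)ccn1` changes that same group once more, with methoxymethyl in place of cyclopropyl on an aromatic carbon. Among the compounds with values here, only one measured step bears on this change, and it is a 1.8-fold lower number from compound 1 to compound 2 (0.24 log units; within the scatter). Within the data shown here, no measured compound yet carries methoxymethyl, so this single small step is a thin guide, and it gives no firm direction. No step beyond the scatter is therefore expected in this assay. The expected step is a 1.4-fold higher number from compound 2 to compound 3 (0.14 log units; within the scatter). For compound 3 the estimated value is 22000 nM, with an expected range from 10000 nM to 45000 nM.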

Compound 3, solubility: 200000 nM
Estimate against measurement, compound 3: 9.1-fold (0.96 log units) below; the whole stated range lies below it.
By their numbers in this assay, from the lowest: compounds 2 and 1 (each within the scatter of the next); then compound 3.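

In this assay, the place next to the ring nitrogen proves able to shift the number strongly, which the earlier pair of dimethylamino and cyclopropyl, lying within the scatter of each other, gave no sign of. Methoxymethyl brings a 13-fold higher number from compound 2 to compound 3 (1.10 log units; beyond the scatter) against cyclopropyl and a 7.1-fold higher number from compound 1 to compound 3 (0.85 log units; beyond the scatter) against dimethylamino, so it stands clear of both earlier groups, even though it has the same count of 3 heavy atoms as cyclopropyl. No measurement shown here explains why this group stands apart from the other two.

Compound 3 differs from compound 2 in two ways at once, gaining an oxygen with its hydrogen-bond acceptor and losing the three-membered ring, and the compounds shown cannot say which of these goes with the higher number. A plain propyl chain, which has no ring and no oxygen, would help to separate the two, while hydroxymethyl or the longer methoxyethyl chain would show how far the result carries to other oxygen-bearing groups at this place.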